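Changing the aryl group on the shared core

The source may report more compounds than this note shows. Statements on the series, on what has been measured and on what is new or still open speak of the compounds shown alone.

Three compounds that share one core were tested in a functional assay on CHO cells for agonist activity at Free fatty acid receptor 1 (Homo sapiens), read by FLIPR and calcium flux, tested at 100 nM; a higher number here means a stronger effect of the compound at the concentration tested, a lower number a weaker effect:
compound 1, `Cc1nc(-c2cccs2)sc1COc1ccc2c(c1)OCC2CC(=O)O`, gives 35.2%
compound 2, `Cc1nc(-c2ccsc2)sc1COc1ccc2c(c1)OCC2CC(=O)O`, gives 56.5%
compound 3, `Cc1cccc(-c2nc(C)c(COc3ccc4c(c3)OCC4CC(=O)O)s2)c1`, gives 47.2%

Compound 3 sits second highest of the three numbers. Its nearest neighbour is compound 2, and the step of a number 9.3 percentage points lower from compound 2 to compound 3 (within the scatter) lies within the scatter, so the two cannot be ordered. Its furthest is compound 1, and the step of a number 12 percentage points higher from compound 1 to compound 3 (beyond the scatter) lies beyond the scatter. Going by the values given here, the only other step, a number 21.3 percentage points higher from compound 1 to compound 2 (beyond the scatter), is also beyond the scatter.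

Compound 4, `Cc1nc(-c2ccccc2F)sc1COc1ccc2c(c1)OCC2CC(=O)O`, differs from compound 3 in one place: 2-fluorophenyl in place of 3-methylphenyl on an aromatic carbon. Both steps that end in compound 3 changed the same group on the same aromatic carbon, and both were modest in size. Among the compounds with values here, none of them involved a 2-fluorophenyl group, so there is no direct measured precedent for this change. Given that all three aryl variants fall within a modest band in this assay, a step of no more than the modest size seen so far is expected, with no clear direction. Compound 4 is therefore estimated at 45%, between 25% and 65%, which corresponds to an expected step of a number 2.2 percentage points lower from compound 3 to compound 4 (within the scatter).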

Compound 4, a percentage reported as activity, at one concentration (the size of the read-out at that concentration, not a potency): 25.8%
Estimate against measurement, compound 4: 19.2 percentage points above; the range from low to high includes it.
By their numbers in this assay, from the lowest: compounds 4 and 1 (each within the scatter of the next); then compounds 3 and 2 (each within the scatter of the next).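

At this aromatic carbon, next to the ring nitrogen and the ring sulfur, the aryl group matters more in this assay than the first three compounds showed: 2-fluorophenyl gives the first large step, a number 30.7 percentage points lower from compound 2 to compound 4 (beyond the scatter), together with a modest one, a number 21.4 percentage points lower from compound 3 to compound 4 (beyond the scatter). The 3-methylphenyl and 2-fluorophenyl groups have the same heavy-atom count and the same ring type, so a change that leaves both of these as they were is still enough to produce a step beyond the scatter, whereas the step of a number 9.4 percentage points lower from compound 1 to compound 4 (within the scatter) lies within the scatter, and those two compounds cannot be ordered. Nothing available gives a reason for these differences.

The compounds shown do not separate the effect of the fluorine from that of its place on the phenyl ring, since the methyl and the fluorine stand at different numbered positions in the two groups. They also leave open how a plain phenyl group, or a phenyl carrying a methoxy group or an amine, would read at this same carbon.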